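This account rests on a few compounds, and the source may have more. Where it says the series, first, only, none or still open, it means among the compounds named here.

Compound 1 `CCCCCCCCCCCCOc1ccc(C(=O)/C=C/c2c(/C=C/c3ccc(OC)cc3)cc(OC)cc2OC)cc1`: 11.6 ug/mL
Compound 2 `CCCCOc1ccc(C(=O)/C=C/c2c(/C=C/c3ccc(OC)cc3)cc(OC)cc2OC)cc1`: 12.9 ug/mL
Compound 3 `CCCCCCOc1ccc(C(=O)/C=C/c2c(/C=C/c3ccc(OC)cc3)cc(OC)cc2OC)cc1`: not yet measured

These values come from a functional assay on HepG2 cells (Homo sapiens) for antiproliferative activity, read by MTT assay, with a stated time of 48 h; a lower number here means a stronger inhibitor, a higher number a weaker inhibitor. Among the measured compounds shown here, the one measured step is a 1.1-fold higher number from compound 1 to compound 2 (0.05 log units; within the scatter), so neither compound ranks above the other, and the standing of the second is level with the first. The next change is ethyl in place of hydrogen on a saturated chain carbon, four bonds along the chain from an oxygen on an aromatic ring. For the measured compounds named here, the resulting chain is longer than the one in compound 2 and shorter than the one in compound 1. That measured step spans the larger change in chain and stayed small, so no shift beyond the scatter is expected. The expected step is a 1.0-fold lower number from compound 2 to compound 3 (0.02 log units; within the scatter). For compound 3 the estimated value is 12.3 ug/mL, with an expected range of 8 ug/mL to 18 ug/mL.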

Compound 3, half-maximal inhibitory concentration: 16.2 ug/mL
Compound 3: the middle estimate sits 1.3-fold (0.12 log units) below what was measured; the range from low to high includes it.
By their numbers in this assay, from the lowest: compounds 1, 2 and 3 (each within the scatter of the next).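

In this assay, among the compounds shown here, a third chain length on this oxygen still separates no compounds. Ethyl in place of hydrogen on the saturated chain carbon gives a 1.3-fold higher number from compound 2 to compound 3 (0.10 log units; within the scatter), and hydrogen in place of hexyl gives a 1.4-fold higher number from compound 1 to compound 3 (0.15 log units; within the scatter). There is no measured evidence here that could explain this flat result.

For the compounds shown here, whether a chain longer than the one in compound 1 would behave the same remains open. So does the effect of an amine or a carboxylic acid at the end of the chain.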